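This account rests on a few compounds, and the source may have more. Where it says the series, first, only, none or still open, it means among the compounds named here.

Compound 1 `CC1=CC[C@H](C(C)(C)NC(=S)N/N=C/c2ccccc2)CC1`: 47600 nM
Compound 2 `CC1=CC[C@H](C(C)(C)NC(=S)N/N=C/c2ccc(O)cc2)CC1`: a limit, > 100000 nM

In a functional assay on K562 cells (Homo sapiens) for inhibition, read by sulforhodamine B assay, with a stated time of 48 h (a lower number here means a stronger inhibitor of growth, a higher number a weaker inhibitor of growth), compound 1 gives 47600 nM. Compound 2 gives only a limit of the assay, > 100000 nM. That is an at least 2.1-fold higher number from compound 1 to compound 2 (0.32 log units; beyond the scatter), and compound 2 therefore stands at the weaker end of the two, at the limit where (the limit of > 100000 nM in this assay, at which 1 of the 2 values shown sits). Compound 3 `CC1=CC[C@H](C(C)(C)NC(=S)N/N=C/c2ccc(N(C)C)cc2)CC1` differs from compound 2 by dimethylamino in place of hydroxy on an aromatic carbon. For the measured compounds named here, no measured step covers this change; the only step, adding hydroxy, raised the number. Removing the hydroxy is expected to bring compound 3 back toward compound 1, an estimated at least 1.8-fold lower number from compound 2 to compound 3 (0.25 log units; that floor lies within the scatter). Compound 3 is therefore estimated at 55000 nM, between 18000 nM and 170000 nM.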

Compound 3, concentration for total growth inhibition: > 100000 nM
Compound 3: a limit, no number; the forecaster's own chance of this, stated with the estimate: 45%; at least 1.8-fold (0.25 log units) between middle value and limit.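

In this assay, dimethylamino in place of hydrogen on the aromatic carbon gives an at least 2.1-fold higher number from compound 1 to compound 3 (0.32 log units; beyond the scatter). A higher number at this position therefore no longer belongs to hydroxy alone: it also appears with a group that carries no hydrogen-bond donor. How compound 2 and compound 3 compare cannot be read, because each gives only a limit: the limit of > 100000 nM in this assay, at which 2 of the 3 values shown sit.

On these data alone, whether chlorine or a methoxy group at this position would also raise the number remains open. So does whether any group here could give a lower number than compound 1.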